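This account rests on a few compounds, and the source may have more. Where it says the series, first, only, none or still open, it means among the compounds named here.

In a functional assay on A549 cells (Homo sapiens) for cytotoxicity, read by MTT assay, with a stated time of 4 days (on this read-out higher numbers stand for weaker inhibition and lower numbers for stronger inhibition), compound 3 `C=C1C(=O)[C@]23C[C@@]1(O)CC[C@H]2c1ccc(OS(=O)(=O)c2ccc(C)cc2)c(C)c1[C@@H]3Cn1cc(-c2ccc(OC)cc2)nn1` gives 1470 nM. Compound 1 `C=C1C(=O)[C@]23C[C@@]1(O)CC[C@H]2c1ccc(OS(=O)(=O)c2ccc(C)cc2)c(C)c1[C@@H]3Cn1cc(-c2ccc(C)cc2)nn1` differs from it by methyl in place of methoxy on an aromatic carbon, and in this assay compound 1 gives 1830 nM. The step is a 1.2-fold higher number from compound 3 to compound 1 (0.10 log units; within the scatter), so the two values are not distinguished here.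

Compound 2 `C=C1C[C@]23C[C@@]1(O)CC[C@H]2c1ccc(O)c(C)c1[C@@H]3Cn1cc(-c2ccc(OC)cc2)nn1` rests on another core; the difference between the two cores is not broken down here. For compound 2 this assay reports only a limit, > 20000 nM, and this is the limit of > 20000 nM in this assay, at which 1 of the 3 values shown sits.

Compound 4 `C=C1C[C@]23C[C@@]1(O)CC[C@H]2c1ccc(O)c(C)c1[C@@H]3Cn1cc(-c2ccc(C)cc2)nn1` has not yet been measured. It stands to compound 2 as compound 1 stands to compound 3, with the same change, methyl in place of methoxy on an aromatic carbon. Because the measured step of a 1.2-fold higher number from compound 3 to compound 1 (0.10 log units; within the scatter) lay within the scatter, the step expected from compound 2 to compound 4 is a step that the limit leaves unreadable from compound 2 to compound 4. Compound 4 is therefore expected to give about 25000 nM, likely between 12000 nM and 60000 nM, and most probably again only a limit.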

Compound 4, half-maximal inhibitory concentration: > 20000 nM
Compound 4 was reported as a limit; the forecaster's own chance of this, stated with the estimate: 70%; the middle value is on the limit's open side.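

Compound 2 and compound 4 are both reported only as limits in this assay, so no step between them can be read: the limit of > 20000 nM in this assay, at which 2 of the 4 values shown sit.

The compounds shown leave open what the change from 4-methoxyphenyl to 4-methylphenyl does on the core of compound 2, where neither compound has a measured number.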